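From allyloxy to hexyloxy on a shared core

The source may hold more compounds than are shown below. What is called first, only, known or untested is meant among the compounds shown, and "the series" means these compounds.

Measured in a functional assay on SK-OV-3 cells (Homo sapiens) for cytotoxicity, read by MTT assay, with a stated time of 48 h; on this read-out higher numbers stand for weaker inhibition and lower numbers for stronger inhibition:
compound 1 `CN(C)CCNc1ccnc2cc(OCc3ccccc3)ccc12`: 2350 nM
compound 2 `C=CCOc1ccc2c(NCCN(C)C)ccnc2c1`: 1560 nM

In this assay compound 2 gives 1560 nM. That lies within the usual scatter of compound 1, so these two numbers cannot be ranked.

Compound 3 `CCCCCCOc1ccc2c(NCCN(C)C)ccnc2c1` has not been measured yet. It keeps the core and side chain of compound 2 and alters one group: pentyl in place of vinyl on a saturated chain carbon bound to an oxygen on an aromatic ring. Put simply, this is allyloxy to hexyloxy, with pentyl in place of vinyl on a saturated chain carbon bound to an oxygen on an aromatic ring.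

For the measured compounds named here, only one measured step bears on this change, since it concerns the same place: a 1.5-fold lower number from compound 1 to compound 2 (0.18 log units; within the scatter). That step replaced phenyl with vinyl, so it says nothing direct about a longer saturated chain. It gives no direction to follow and only thin evidence on size. No shift beyond the scatter is therefore expected, though the range must stay wide.

The expected change is a 1.0-fold lower number from compound 2 to compound 3 (0.02 log units; within the scatter).

For compound 3 the estimated value is 1500 nM, with an expected range of 600 nM to 3800 nM.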

Compound 3, half-maximal inhibitory concentration: 1860 nM
For compound 3 the middle estimate is 1.2-fold (0.09 log units) below the measured one; low and high end bracket the measured number.
By their numbers in this assay, from the lowest: compounds 2, 3 and 1 (each within the scatter of the next).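

Going from allyloxy to hexyloxy adds a longer saturated chain at this position, yet in this assay the step is a 1.2-fold higher number from compound 2 to compound 3 (0.08 log units; within the scatter) and the two compounds cannot be told apart. The other comparison, pentyl in place of phenyl, gives a 1.3-fold lower number from compound 1 to compound 3 (0.10 log units; within the scatter) and is just as unreadable as a ranking. The earlier compounds shown here had only compared a ring with a short unsaturated group, so this result adds something new: at this place on the shared core, phenyl, vinyl and pentyl all give numbers within the scatter of one another, and neither a ring, a double bond nor the longer saturated chain separates these three compounds in this assay. No measurement is available here that could explain this flat picture.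

The compounds shown leave open whether a group of a different kind at this place, such as a chain ending in an amine or a carboxylic acid, would move the number beyond the scatter. They also leave open whether a longer chain than hexyl would stay within the scatter of these three compounds.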